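The source may hold more compounds than are shown below. What is called first, only, known or untested is meant among the compounds shown, and "the series" means these compounds.

The three measured compounds share one core and differ only in the group on a saturated ring carbon. Compound 1 `CO[C@H]1C(=O)N2C(C(=O)C(C)(C)C)=C(C)[C@@H](Sc3nnc(C)s3)S(=O)(=O)C12` gives 27 h in a physicochemical assay, at pH 7.4 (on this read-out lower numbers stand for a shorter-lived compound and higher numbers for a longer-lived compound), and compound 2 `CO[C@H]1C(=O)N2C(C(=O)C(C)(C)C)=C(C)[C@@H](Sc3nc(=O)c(=O)[nH]n3C)S(=O)(=O)C12` gives 21 h in this assay; the step of a 1.3-fold lower number from compound 1 to compound 2 (0.11 log units; within the scatter) stays within the scatter. Compound 3 `CO[C@H]1C(=O)N2C(C(=O)C(C)(C)C)=C(C)[C@@H](OC(C)=O)S(=O)(=O)C12` gives 6.3 h in this assay, the lowest of the three numbers, and the steps of a 4.3-fold lower number from compound 1 to compound 3 (0.63 log units; beyond the scatter) and a 3.3-fold lower number from compound 2 to compound 3 (0.52 log units; beyond the scatter) both lie beyond the scatter. Compound 4 `CO[C@H]1C(=O)N2C(C(=O)C(C)(C)C)=C(C)[C@@H](OC(=O)CCC(=O)c3ccccc3)S(=O)(=O)C12` keeps the ester of compound 3 and lengthens it: benzoylmethyl in place of hydrogen on a saturated chain carbon bound to a carbonyl carbon. Within the data shown here, none of the measured steps bears directly on this change, since each of them exchanges the whole group on the saturated ring carbon for a group of another kind, whereas here the ester is retained and only its chain grows. Among the measured compounds shown here, the measured steps that did move the number were modest, and nothing among the measured compounds shows how one ester compares with another. The chemist therefore expects for compound 4 a step of a 1.0-fold higher number from compound 3 to compound 4 (0.01 log units; within the scatter), which is within the scatter. Compound 4 is accordingly estimated at 6.5 h in this assay, with a range from 3.5 h to 12 h.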

Compound 4, half-life: 13 h
Estimate against measurement, compound 4: 2.0-fold (0.30 log units) below; the measured number lies above the stated range.
By their numbers in this assay, from the lowest: compound 3; then compounds 4, 2 and 1 (each within the scatter of the next, the first and the last beyond it).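

In this assay the change of methyl to 2-benzoylethyl on the ester gives a 2.1-fold higher number from compound 3 to compound 4 (0.31 log units; beyond the scatter) and so lies beyond the scatter, though the step is modest. The earlier steps shown here each exchanged the whole group on the saturated ring carbon, so they could not separate the ester from what it carries; this step shows that, with the ester kept, a change further out on its chain is enough by itself to move the half-life. Nothing in the data shown explains why the number moves with this change.

The compounds shown leave open which part of the benzoylmethyl group goes with the step: the phenyl ring, the ketone carbonyl or simply the longer chain, a question that a plain saturated alkyl chain of similar length on the ester would help to settle. They also leave open how the half-life would respond to a carboxylic acid or an amine at the end of the chain, or to a substituent on the phenyl ring.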